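Amide nitrogen substituent: carbamoylmethyl exchanged for 4-chlorophenyl

The compounds below may be only part of what the source reports. "The series", "measured", "known", "first", "only" and "open" are said of these compounds alone.

compound 1 `Cc1c(C(C)C)c(=O)on1C(=O)N(C)Cc1ccco1`: 4 nM
compound 2 `Cc1c(C(C)C)c(=O)on1C(=O)N(C)CC(N)=O`: > 1000 nM
compound 3 `Cc1c(C(C)C)c(=O)on1C(=O)N(C)c1ccc(Cl)cc1`: not yet measured

In an assay (strain Wistar) for inhibition of Hormone-sensitive lipase (Rattus norvegicus), read by spectrophotometry (a lower number here means a stronger inhibitor, a higher number a weaker inhibitor), compound 1 gives 4 nM. Compound 2 is known only as a limit, > 1000 nM, and sits at the limit of > 1000 nM in this assay, at which 1 of the 2 values shown sits. Among the measured compounds shown here, the one measured step, an at least 250-fold higher number from compound 1 to compound 2 (2.39 log units; beyond the scatter), therefore runs from a number to a limit, and its true size is not known. Compound 3 differs from compound 2 by 4-chlorophenyl in place of carbamoylmethyl on an amide-type nitrogen. The measured step bears on this only loosely: it concerns the saturated chain carbon, not the amide-type nitrogen itself. Still, compound 2 is the weaker of the two measured compounds, so removing its carbamoyl-bearing chain is expected to lower the number, by an at least 50-fold lower number from compound 2 to compound 3 (1.69 log units; beyond the scatter). Compound 3 is estimated at 20 nM (3 nM to 300 nM).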

Compound 3, half-maximal inhibitory concentration: 17 nM
The estimate for compound 3 lay 1.2-fold (0.07 log units) above the measured number; the measured number falls inside the stated range.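

Compound 2 is held only as a limit: the limit of > 1000 nM in this assay, at which 1 of the 3 values shown sits.

Exchanging carbamoylmethyl for 4-chlorophenyl gives an at least 58-fold lower number from compound 2 to compound 3 (1.76 log units; beyond the scatter), a size known only as a floor, and shows that a ring of carbon only on the amide-type nitrogen also gives a low number. Set against (furan-2-yl)methyl, the same group gives only a 4.3-fold higher number from compound 1 to compound 3 (0.63 log units; beyond the scatter), a modest step compared with the large one.

From the compounds shown here alone, whether this modest step follows the ring type, the chain carbon or the chlorine stays open. A benzyl or an unsubstituted phenyl group on this nitrogen would help separate these.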